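Urea series: inverted stereocentre, compound 3 to compound 4

A few compounds are considered here, and "the series" means these few. Any claim that something is new, unique, unknown or untested is made for them only; others in the source may bear on it.

Compound 1 `C[C@H](NC(=O)Nc1ccccc1F)c1ccccc1` gives 92% in an ADME assay on the whole organism with Oryza sativa as the target, tested at 1 uM; a lower number here means a stronger effect, a higher number a weaker effect of the compound at the concentration tested.
Compound 2 `C[C@H](NC(=O)Nc1cc(F)ccc1F)c1ccccc1` gives 98% in this assay.
Compound 3 `C[C@@H](NC(=O)Nc1cc(C(F)(F)F)ccc1F)c1ccccc1` gives 70% in this assay.

Compound 3 stands lowest of the three numbers in this assay; its distance to compound 1 and to compound 2 lies beyond the scatter in both cases. Among the compounds with values here, the only step between measured compounds, a number 6 percentage points higher from compound 1 to compound 2 (within the scatter), concerns a ring substituent and says nothing about configuration.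

Compound 4 `C[C@H](NC(=O)Nc1cc(C(F)(F)F)ccc1F)c1ccccc1` differs from compound 3 as follows: the two compounds have the same atoms and bonds and differ only in configuration as drawn: 1 of 1 stereo elements differ; a stereocentre at a saturated chain carbon is drawn R in compound 3 and S in compound 4. Within the data shown here, no measured step bears on this change, so no direction can be expected and the step of a number 5 percentage points higher from compound 3 to compound 4 (within the scatter) is taken as an estimate near zero with a wide range. Compound 4 is therefore expected to give about 75% in this assay, between 50% and 98%, resting only on the value of compound 3, 70%.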

Compound 4, a percentage reported as activity, at one concentration (the size of the read-out at that concentration, not a potency): 89%
Compound 4: middle estimate off by 14 percentage points, on the low side, and the stated range covers the measured number.
By their numbers in this assay, from the lowest: compound 3; then compounds 4, 1 and 2 (each within the scatter of the next).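

The stereocentre at the saturated chain carbon counts in this assay: drawing it S rather than R gives a number 19 percentage points higher from compound 3 to compound 4 (beyond the scatter), and this difference can be assigned to configuration alone: the fact that compounds 3 and 4 differ only in the configuration as drawn.
Among compounds sharing the configuration of compound 4, trifluoromethyl in place of fluoro gives a number 9 percentage points lower from compound 2 to compound 4 (within the scatter), and trifluoromethyl in place of hydrogen gives a number 3 percentage points lower from compound 1 to compound 4 (within the scatter).
Trifluoromethyl therefore shows no step beyond the scatter in that configuration, and the low number of compound 3 is tied to its R centre.

Still open, on these data alone, is whether the gap between the two configurations persists with a nitrile in place of trifluoromethyl, or with an ethyl in place of the methyl on the stereocentre.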